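The source may hold more compounds than are shown below. What is called first, only, known or untested is meant among the compounds shown, and "the series" means these compounds.

Measured compounds:
compound 1 `Cc1ccccc1NC(=O)N[C@H](C)c1ccccc1`, 100%
compound 2 `Cc1ccccc1NC(=O)N[C@@H](C)c1ccccc1`, 99%
compound 3 `CCCCc1ccc(NC(=O)N[C@H](C)c2ccccc2)cc1`, 32%

In an ADME assay on the whole organism with Oryza sativa as the target, tested at 1 uM (a lower number here means a stronger effect, a higher number a weaker effect of the compound at the concentration tested), compound 1 gives 100% and compound 2 gives 99%. Within the data shown here, the step of a number 1 percentage points lower from compound 1 to compound 2 (within the scatter) is the only one between compounds that differ in one place, and it is explained by the fact that compounds 1 and 2 differ only in the configuration as drawn. Among the measured compounds shown here, compound 3 gives 32%, which is the lowest of the three numbers, but it differs from compound 2 in more than one place, so no single step can be drawn from it. Compound 2 therefore stands second highest of the three numbers, within the scatter of compound 1 and far from compound 3.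

The untested compound 4 `CC(=O)c1ccccc1NC(=O)N[C@@H](C)c1ccccc1` arises from compound 2 by acetyl in place of methyl on an aromatic carbon, placed on an aromatic carbon of a six-membered aromatic ring of carbon only, ortho to a large group. For the measured compounds named here, no measured step follows this kind of change; the one measured step was a change of configuration alone and was within the scatter. Compound 4 is therefore expected to stay near compound 2, with the step of a number 9 percentage points lower from compound 2 to compound 4 (within the scatter) estimated as small, possibly not beyond the scatter. Compound 4 is estimated at 90%, in the range 60% to 100%.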

Compound 4, a percentage reported as activity, at one concentration (the size of the read-out at that concentration, not a potency): 97%
Compound 4: the middle estimate sits 7 percentage points below what was measured; the measured number falls inside the stated range.
By their numbers in this assay, from the lowest: compound 3; then compounds 4, 2 and 1 (each within the scatter of the next).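

In this assay, acetyl in place of methyl on an aromatic carbon, ortho to a large group, gives a number 2 percentage points lower from compound 2 to compound 4 (within the scatter). The earlier compounds shown here showed only a change of configuration, whereas this step shows that a change of the group itself at this place, one that brings in a hydrogen-bond acceptor and a double bond outside aromatic rings, can also stay within the scatter. Nothing in the information at hand accounts for this particular step.

As far as these compounds go, it remains open whether an amine, a carboxylic acid or a longer chain on this aromatic carbon would give a step beyond the scatter. Also open is which of the places where compound 2 and compound 3 differ lies behind compound 3 giving 32%.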